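Removing the Trifluoromethyl Group from Compound 3

The source may report more compounds than this note shows. Statements on the series, on what has been measured and on what is new or still open speak of the compounds shown alone.

Compound 1 `CCOC(=O)c1sc(-c2cccc(NC(=O)c3ccc(C(F)(F)F)cc3)c2)nc1Nc1ccc(N2CCN(C)CC2)cc1` gives 18.4%
Compound 2 `CCOC(=O)c1sc(-c2cccc(NC(=O)c3ccc(C#N)cc3)c2)nc1Nc1ccc(N2CCN(C)CC2)cc1` gives 97.5%
Compound 3 `CN1CCN(c2ccc(Nc3nc(-c4cccc(NC(=O)c5ccc(C(F)(F)F)cc5)c4)sc3C(N)=O)cc2)CC1` gives 97.8%

These three compounds were measured in a functional assay on Ramos cells (Homo sapiens) for antiproliferative activity, read by CCK-8 assay, with a stated time of 72 h, tested at 40 uM; a lower number here means less inhibition, a higher number more inhibition at the concentration tested (going by the name of the read-out). Compound 3 stands highest of the three numbers; compound 2 sits within the scatter of it, while compound 1 lies far below. Two steps have been measured: a number 79.1 percentage points higher from compound 1 to compound 2 (beyond the scatter), and a number 79.4 percentage points higher from compound 1 to compound 3 (beyond the scatter). Both start from compound 1, whose number is the lowest of the three, and both are large.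

Compound 4 `CN1CCN(c2ccc(Nc3nc(-c4cccc(NC(=O)c5ccccc5)c4)sc3C(N)=O)cc2)CC1` differs from compound 3 by hydrogen in place of trifluoromethyl on an aromatic carbon. Going by the values given here, no measured step removes the trifluoromethyl group outright, so neither step bears on it directly. The closest hint is the step from compound 1 to compound 2, where replacing trifluoromethyl with cyano on the same aromatic carbon gave a large rise in this assay; the trifluoromethyl group therefore did not carry the inhibition in that pair. Compound 3, however, already stands near the top of the scale, so there is little room to go up, and the expected step from compound 3 to compound 4 is a number 9.8 percentage points lower from compound 3 to compound 4 (within the scatter), small or within the scatter. For compound 4 the expected value in this assay is 88%, with a range from 50% to 99%.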

Compound 4, a percentage reported as inhibition, at one concentration (the size of the read-out at that concentration, not a potency): 98.1%
Compound 4: middle estimate off by 10.1 percentage points, on the low side; measured number inside the range.
By their numbers in this assay, from the lowest: compound 1; then compounds 2, 3 and 4 (each within the scatter of the next).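

In this assay, the step of a number 0.3 percentage points higher from compound 3 to compound 4 (within the scatter) shows that the trifluoromethyl group can be removed altogether from this position, para to a large group, without a change beyond the scatter, so 4-(trifluoromethyl)phenyl and plain phenyl cannot be told apart here in compounds that carry the primary carboxamide. The earlier compounds shown here showed only a replacement of trifluoromethyl by cyano, and that in the ethyl ester setting, whereas this pair shows that, on the carboxamide, no substituent is needed on that aromatic carbon for the inhibition seen at this single concentration. Nothing at hand gives a cause for this result.

Both compounds stand close to the top of the scale, so a single-concentration read-out leaves open whether compound 3 and compound 4 differ in potency at lower concentrations. Also open, as far as these compounds go, are what an amine or a carboxylic acid on that same aromatic carbon would do, and whether hydrogen at this position would lift the low number of the ethyl ester compound 1 as cyano did.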